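Notes on the series: the step to compound 3

This account rests on a few compounds, and the source may have more. Where it says the series, first, only, none or still open, it means among the compounds named here.

Measured in a functional assay on DU-145 cells (Homo sapiens) for inhibition, read by trypan blue exclusion, with a stated time of 96 h; on this read-out higher numbers stand for weaker inhibition of growth and lower numbers for stronger inhibition of growth:
- compound 1 `Cc1ccc(CS/C(=C/c2ccccc2F)C(=O)c2ccc(Cl)cc2)cc1`: 10000 nM
- compound 2 `CSc1ccc(/C=C(/SCc2ccc(C)cc2)C(=O)c2ccc(Br)cc2)cc1`: > 100000 nM

The value of compound 2, > 100000 nM, is a limit of the assay and not a number.

Compound 3 `Cc1ccc(CS/C(=C/c2ccccc2F)C(=O)c2ccc(Br)cc2)cc1` carries 2-fluorophenyl in place of 4-(methylsulfanyl)phenyl on a double-bonded chain carbon bound to a double-bonded chain carbon.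

Compound 1 also carries 2-fluorophenyl and gives 10000 nM, so stronger inhibition of growth, well beyond the scatter, is expected in this assay. The expected size is an at least 10-fold lower number from compound 2 to compound 3 (1.00 log units; beyond the scatter). The estimate for compound 3 is 10000 nM, with an expected range of 2500 nM to 50000 nM.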

Compound 3, concentration for 50% growth inhibition: 10000 nM
Compound 3: middle estimate and measured number agree at the digits printed, within the range that was stated.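

In this assay, for the compounds shown here, 2-fluorophenyl in place of 4-(methylsulfanyl)phenyl on a double-bonded chain carbon bound to a double-bonded chain carbon gives an at least 10-fold lower number from compound 2 to compound 3 (1.00 log units; beyond the scatter), the first readable single change at this place. Compound 2 stands at a limit of the assay, so this step has a floor and no measured size: the limit of > 100000 nM in this assay, at which 1 of the 3 values shown sits.

Bromo in place of chloro on an aromatic carbon gives no change at the digits printed from compound 1 to compound 3 (within the scatter), so this change does not separate the two compounds while 2-fluorophenyl is present.

Open, on these data alone, is whether a plain phenyl or a 4-(dimethylamino)phenyl at this place would read nearer compound 3 or compound 2. Also open, as far as these compounds go, is how bromo in place of chloro reads with 4-(methylsulfanyl)phenyl present.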